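A few compounds are considered here, and "the series" means these few. Any claim that something is new, unique, unknown or untested is made for them only; others in the source may bear on it.

Measured in a functional assay on KB cells (Homo sapiens) for antiproliferative activity, read by colorimetric assay and MTT assay; on this read-out lower numbers stand for stronger inhibition and higher numbers for weaker inhibition:
- compound 1 `O=S(=O)(Nc1cccc2c(Cl)c[nH]c12)c1ccc(Cl)cc1`: 8.8 ug/mL
- compound 2 `O=[N+]([O-])c1ccc(S(=O)(=O)Nc2cccc3c(Cl)c[nH]c23)cc1`: 14 ug/mL
- compound 3 `Nc1ccc(S(=O)(=O)Nc2cccc3cc[nH]c23)cc1`: 36 ug/mL

Of these three, compound 3 has the highest number, and its gap to each of the other two lies beyond the usual scatter. Compound 4 `Nc1ccc(S(=O)(=O)Nc2cccc3c(Cl)c[nH]c23)cc1` keeps the amino group of compound 3 and differs from it at one place: chloro in place of hydrogen on an aromatic carbon. This is chloro in place of hydrogen on an aromatic carbon.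

Going by the values given here, no measured pair shows this change on its own. Among the compounds with values here, the only measured step, a 1.6-fold higher number from compound 1 to compound 2 (0.20 log units; within the scatter), concerns a different place, but it suggests that compound 1 and compound 2 read alike despite their different groups there. Both also carry the chloro on the five-membered aromatic ring, and both have lower numbers than compound 3: compound 1 gives 8.8 ug/mL and compound 2 gives 14 ug/mL. However, they also lack the amino group, so the comparison is indirect. A drop in the number is therefore expected, but its size is uncertain.

The expected change is a 2.8-fold lower number from compound 3 to compound 4 (0.44 log units; beyond the scatter). For compound 4 the estimated value is 13 ug/mL, with an expected range from 5 ug/mL to 32 ug/mL.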

Compound 4, half-maximal inhibitory concentration: 10 ug/mL
The estimate for compound 4 lay 1.3-fold (0.11 log units) above the measured number, and the stated range covers the measured number.
By their numbers in this assay, from the lowest: compounds 1, 4 and 2 (each within the scatter of the next); then compound 3.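

In this assay, chloro in place of hydrogen on an aromatic carbon of the five-membered aromatic ring gives a 3.6-fold lower number from compound 3 to compound 4 (0.56 log units; beyond the scatter), and this pair reads that change directly, with the amino group present in both compounds. With the chloro held in place, swapping the other group makes no clear difference in these three compounds: amino in place of nitro gives a 1.4-fold lower number from compound 2 to compound 4 (0.15 log units; within the scatter), and amino in place of chloro gives a 1.1-fold higher number from compound 1 to compound 4 (0.06 log units; within the scatter), so among the compounds shown only the one lacking the chloro stands apart. Nothing measured here explains why this single atom shifts the number.

On these data alone, only hydrogen and chloro appear at this position, so what a bromo, a methyl or a nitrile would do on the same carbon stays open. Also open, as far as these compounds go, is whether chloro in place of hydrogen gives a similar step when the nitro group of compound 2 or the other chloro of compound 1 stands where compound 4 has its amino group, since only the amino pair shows this change.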